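A few compounds are considered here, and "the series" means these few. Any claim that something is new, unique, unknown or untested is made for them only; others in the source may bear on it.

Measured compounds:
Compound 1, `Nc1ncnn2c([C@@H]3O[C@H](CO)[C@@H](O)[C@H]3O)cc(C#CC3CC3)c12`: 80 nM
Compound 2, `Nc1ncnn2c([C@@H]3O[C@H](CO)[C@@H](O)[C@H]3O)cc(-c3ccc(Cl)cc3)c12`: 45900 nM

Both were tested in a functional assay on NCI-H460 cells (Homo sapiens) for antiproliferative activity, with a stated time of 72 h; on this read-out higher numbers stand for weaker inhibition and lower numbers for stronger inhibition. Of the two numbers, compound 1 stands at the lower one, and compound 2 lies far away from it: a 570-fold higher number from compound 1 to compound 2 (2.76 log units; beyond the scatter). Compound 3, `COc1ccc(-c2cc([C@@H]3O[C@H](CO)[C@@H](O)[C@H]3O)n3ncnc(N)c23)cc1`, has not yet been measured. Its change from compound 1 is 4-methoxyphenyl in place of 2-cyclopropylethynyl on an aromatic carbon. For the measured compounds named here, only one measured step bears on this: in compound 2 the 2-cyclopropylethynyl group likewise gives way to a six-membered aromatic ring of carbon only, and the result was a 570-fold higher number from compound 1 to compound 2 (2.76 log units; beyond the scatter), a large loss of inhibition. Since a six-membered aromatic ring of carbon only enters again at the same aromatic carbon, a similar outcome is expected, that is, a large step toward weaker inhibition in this assay, estimated as a 380-fold higher number from compound 1 to compound 3 (2.57 log units; beyond the scatter). Compound 3 is estimated at 30000 nM, expected to fall between 5000 nM and 150000 nM.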

Compound 3, half-maximal inhibitory concentration: 69300 nM
Beside the measured number, compound 3's estimate is 2.3-fold (0.36 log units) below it; low and high end bracket the measured number.
By their numbers in this assay, from the lowest: compound 1; then compounds 2 and 3 (each within the scatter of the next).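

In this assay, a second six-membered aromatic ring of carbon only at this aromatic carbon also gives a large step toward weaker inhibition (an 870-fold higher number from compound 1 to compound 3 (2.94 log units; beyond the scatter)). The loss is therefore not confined to 4-chlorophenyl: methoxy in place of chloro on that ring changes the number by no more than the usual scatter (a 1.5-fold higher number from compound 2 to compound 3 (0.18 log units; within the scatter)). Nothing measured here explains the gap between 2-cyclopropylethynyl and these two ring-bearing groups.

The compounds shown leave open whether the triple bond or the three-membered ring in 2-cyclopropylethynyl matters more, a question that a plain ethynyl group or a saturated 2-cyclopropylethyl chain could address. They also leave open whether a group such as an amine or a carboxylic acid on the six-membered ring would change the picture.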